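The source may report more compounds than this note shows. Statements on the series, on what has been measured and on what is new or still open speak of the compounds shown alone.

Measured in a functional assay on MIA PaCa-2 cells (Homo sapiens) for antiproliferative activity, read by sulforhodamine B assay, with a stated time of 48 h (on this read-out higher numbers stand for weaker inhibition and lower numbers for stronger inhibition), so far:
- Compound 1 `COc1cc(OC)c2sc(-c3ccc(N/C=C\C(=O)c4ccc(OC)c([N+](=O)[O-])c4)c(C)c3)nc2c1` gives 13900 nM as its value
- Compound 2 `COc1ccc(C(=O)/C=C\Nc2ccc(-c3nc4cc(OC)c(OC)c(OC)c4s3)cc2C)cc1[N+](=O)[O-]` gives 23400 nM as its value

Only these two compounds have numbers, and compound 1 lies within the scatter of compound 2, so the two cannot be ranked. Within the data shown here, the one measured step is a 1.7-fold higher number from compound 1 to compound 2 (0.23 log units; within the scatter) for methoxy in place of hydrogen on an aromatic carbon, and it stays within the scatter. Both compounds carry the 4-methoxy-3-nitrophenyl group, so that step leaves untouched the group that changes next.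

Compound 3 `COc1cc(OC)c2sc(-c3ccc(N/C=C\C(=O)c4cc(OC)c(OC)c(OC)c4)c(C)c3)nc2c1` differs from compound 1 by 3,4,5-trimethoxyphenyl in place of 4-methoxy-3-nitrophenyl on a carbonyl carbon in a single exchange, 3,4,5-trimethoxyphenyl in place of 4-methoxy-3-nitrophenyl on a carbonyl carbon. Among the measured compounds shown here, no measured step in this assay tests this replacement, so the data offer no direction and no step beyond the scatter is expected, though with little certainty. The expected step is a 1.1-fold lower number from compound 1 to compound 3 (0.03 log units; within the scatter) and it remains a weakly supported estimate. For compound 3 the estimated value is 13000 nM with an expected range from 3500 nM to 45000 nM as the span of likely results.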

Compound 3, half-maximal inhibitory concentration: 17000 nM
Compound 3: middle estimate off by 1.3-fold (0.12 log units), on the low side; measured number inside the range.
By their numbers in this assay, from the lowest: compounds 1, 3 and 2 (each within the scatter of the next).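

In this assay, the exchange of 4-methoxy-3-nitrophenyl for 3,4,5-trimethoxyphenyl on a carbonyl carbon gives a 1.2-fold higher number from compound 1 to compound 3 (0.09 log units; within the scatter), so this first test of the group at this position does not separate the two groups. Among these compounds, the group that leaves carries the only nitro group in the pair, yet compound 3, which has none, gives 17000 nM, so at this position a nitro group is not needed for a number in this range, and both groups count the same number of hydrogen-bond acceptors. Nothing measured here bears on why the exchange leaves the number within the scatter.

The three compounds leave open whether any group on this carbonyl carbon can move the number beyond the scatter, for example a phenyl ring bearing a carboxylic acid or a dimethylamino group, or a plain alkyl chain in place of the ring. On these data alone, the methoxy step on the core has also been read only with 4-methoxy-3-nitrophenyl in place, so its size alongside 3,4,5-trimethoxyphenyl remains unknown.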